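Pyridin-3-yl to ethoxy: the step to compound 3

The source may report more compounds than this note shows. Statements on the series, on what has been measured and on what is new or still open speak of the compounds shown alone.

- compound 1 `O=c1cc(N2CCNCC2)c2ccc(OCc3ccccc3)cc2o1` gives 16300 nM
- compound 2 `Cc1c(OCc2cccnc2)ccc2c(N3CCNCC3)cc(=O)oc12` gives 980 nM

In a functional assay on a cell-free system (plasma, Homo sapiens) for inhibition, with Plasma (Rattus norvegicus) as the target (a lower number here means a stronger inhibitor, a higher number a weaker inhibitor), compound 2 gives 980 nM and stands lowest of the two numbers, with compound 1 at 16300 nM. The gap between these two numbers lies beyond the scatter. Compound 3 `CCOCOc1ccc2c(N3CCNCC3)cc(=O)oc2c1C` has not yet been measured. Its difference from compound 2 is ethoxy in place of pyridin-3-yl on a saturated chain carbon bound to an oxygen on an aromatic ring in a single place, ethoxy in place of pyridin-3-yl on a saturated chain carbon bound to an oxygen on an aromatic ring. Within the data shown here, no measured pair isolates this change, and compound 1 and compound 2 differ in more than one place. A moderate step to a higher number in this assay is expected, probably beyond the scatter. The expected move is a 2.6-fold higher number from compound 2 to compound 3 (0.41 log units; beyond the scatter) on this estimate. For compound 3 the estimate is 2500 nM with an expected range from 700 nM to 9000 nM as its span.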

Compound 3, half-maximal inhibitory concentration: 1800 nM
Estimate against measurement, compound 3: 1.4-fold (0.14 log units) above; the range from low to high includes it.
By their numbers in this assay, from the lowest: compounds 2 and 3 (each within the scatter of the next); then compound 1.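

In this assay, ethoxy in place of pyridin-3-yl on a saturated chain carbon bound to an oxygen on an aromatic ring gives a 1.8-fold higher number from compound 2 to compound 3 (0.26 log units; within the scatter). Among these compounds, this is the first pair that differs in one place, and it shows that the six-membered aromatic ring can give way at this place to a group with no ring and fewer heavy atoms while the two numbers stay within the scatter of each other. Nothing measured here offers an explanation for this result.

Still open, as far as these compounds go, is whether an amine, a carboxylic acid or a longer chain at this place would also stay within the scatter of compound 2. Compound 1 differs from compound 2 in more than one place, and its gap to that compound cannot be assigned to any single one of them.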